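The compounds below may be only part of what the source reports. "The series", "measured", "known", "first", "only" and "open" are said of these compounds alone.

Working notes on the series.

Three members of the series have been measured and one has not. Compound 1 `Cc1cc(N2CCCCC2)c(S(C)(=O)=O)cc1C(=O)N=C(N)N` gives 21 nM in a functional assay for inhibition of sodium/hydrogen exchanger (Oryctolagus cuniculus); a lower number here means a stronger inhibitor, a higher number a weaker inhibitor. Compound 2 `CS(=O)(=O)c1cc(C(=O)N=C(N)N)ccc1N1CCCCC1` gives 130 nM in this assay. Compound 3 `Cc1cc(Oc2cncc(Cl)c2)c(S(C)(=O)=O)cc1C(=O)N=C(N)N` gives 14 nM in this assay, which is the lowest of the three numbers, though its step from compound 1 is within the scatter. Compound 4 `CS(=O)(=O)c1cc(C(=O)N=C(N)N)ccc1Oc1cncc(Cl)c1` is still to be measured in this assay.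

The cores of compound 1 and compound 3 differ by (5-chloropyridin-3-yl)oxy in place of piperidin-1-yl on an aromatic carbon; the step of a 1.5-fold lower number from compound 1 to compound 3 (0.18 log units; within the scatter) shows that this exchange leaves the number where it was.

The change from compound 1 to compound 2 is hydrogen in place of methyl on an aromatic carbon. It made the step of a 6.2-fold higher number from compound 1 to compound 2 (0.79 log units; beyond the scatter), a modest loss. The change from compound 3 to compound 4 is hydrogen in place of methyl on an aromatic carbon. It is the same kind of change, made on the other core: the group that leaves and the hydrogen that enters are the same, and the place is ortho to a group of 6 heavy atoms and para to a methylsulfonyl group in both, but it is meta to a piperidin-1-yl group in compound 1 and meta to a (5-chloropyridin-3-yl)oxy group in compound 3.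

Since the core exchange itself did not move the number, as a 1.5-fold lower number from compound 1 to compound 3 (0.18 log units; within the scatter) shows, the removal of the methyl is expected to cost about as much on the core of compound 3 as it did in a 6.2-fold higher number from compound 1 to compound 2 (0.79 log units; beyond the scatter), so a step of a 6.1-fold higher number from compound 3 to compound 4 (0.78 log units; beyond the scatter) is expected. On that basis compound 4 is estimated at 85 nM in this assay, expected to fall between 35 nM and 210 nM.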

Compound 4, half-maximal inhibitory concentration: 75 nM
Compound 4: the middle estimate sits 1.1-fold (0.05 log units) above what was measured, and the stated range covers the measured number.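

In this assay the removal of the methyl gives a 5.4-fold higher number from compound 3 to compound 4 (0.73 log units; beyond the scatter), and this step agrees with the earlier one on the core of compound 1, so hydrogen in place of methyl carries over between these two cores: the same change on two cores in this assay, a 6.2-fold higher number (0.79 log units; beyond the scatter) from compound 1 to compound 2 and a 5.4-fold higher number (0.73 log units; beyond the scatter) from compound 3 to compound 4, 1.2-fold (0.06 log units) apart, within the scatter of two such steps. The exchange of piperidin-1-yl for (5-chloropyridin-3-yl)oxy, read on the cores without the methyl as a 1.7-fold lower number from compound 2 to compound 4 (0.24 log units; within the scatter), again stays within the scatter, so the two groups cannot be told apart with or without the methyl: the same change on two cores in this assay, a 1.5-fold lower number (0.18 log units; within the scatter) from compound 1 to compound 3 and a 1.7-fold lower number (0.24 log units; within the scatter) from compound 2 to compound 4, 1.2-fold (0.06 log units) apart, within the scatter of two such steps. This agreement covers only these four compounds, with two groups at one place, and it does not show that the methyl step would hold on a core carrying any other group there, nor does it say why the methyl counts.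

Going by these compounds, whether an ethyl or a methoxy group in the place of the methyl would match the methyl in this assay remains open. So does the size of the methyl step when a primary amine or a morpholine takes the place of piperidin-1-yl, or when a nitrile takes the place of the methylsulfonyl group.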